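A few compounds are considered here, and "the series" means these few. Any claim that something is new, unique, unknown or untested is made for them only; others in the source may bear on it.

Three compounds have been measured in a functional assay (brain) for inhibition, with Rattus norvegicus as the target; a lower number here means a stronger inhibitor, a higher number a weaker inhibitor:

Compound 1 `Fc1cccc2[nH]cc(C3CCNCC3)c12`: 60 nM
Compound 2 `Fc1ccc2c(C3CCNCC3)c[nH]c2c1`: 20 nM
Compound 3 `Fc1ccc2[nH]cc(CCCCN3CCNCC3)c2c1`: 0.15 nM

Among these three, compound 2, at 20 nM, has the second highest number. It is a stronger inhibitor than compound 1, at 60 nM, but a much weaker one than compound 3, at 0.15 nM. Both gaps lie beyond the usual scatter.

The next compound to be tested is compound 4 `NCCN1CCC(c2c[nH]c3cc(F)ccc23)CC1`, which is built from compound 2 by one change: 2-aminoethyl in place of hydrogen on an amine nitrogen in a ring. A 2-aminoethyl group thus replaces the hydrogen on the amine nitrogen in the six-membered non-aromatic ring.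

Among the compounds with values here, no measured pair in this set differs in only one place, so the data offer no direct precedent for this change. Within the data shown here, compound 3, at 0.15 nM, shows only that much lower numbers are reachable in this small set, and it differs from compound 2 in more than one place. A modest move toward a lower number therefore seems more likely than a large one, and a result within the scatter of compound 2 would not be surprising.

The expected step is a 2.0-fold lower number from compound 2 to compound 4 (0.30 log units; within the scatter).

For compound 4 the estimated value is 10 nM, with an expected range of 2 nM to 60 nM.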

Compound 4, half-maximal inhibitory concentration: 11 nM
Compound 4: middle estimate off by 1.1-fold (0.04 log units), on the low side; low and high end bracket the measured number.
By their numbers in this assay, from the lowest: compound 3; then compounds 4 and 2 (each within the scatter of the next); then compound 1.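

Within the data shown here, putting 2-aminoethyl in place of hydrogen on the amine nitrogen of the six-membered non-aromatic ring gives a 1.8-fold lower number from compound 2 to compound 4 (0.26 log units; within the scatter) in this assay and is the first single-place comparison in this set. It shows that this nitrogen can carry a chain of this kind while the number stays within the scatter of the parent, something that compounds 1, 2 and 3 could not show, since no two of them differed in only one place. Nothing at hand explains this outcome or links it to any property of the group.

This single step cannot say whether the same holds for other groups on that nitrogen, such as methyl, an acetyl group, a carboxylic acid or a longer chain ending in an amine, any of which could move the number beyond the scatter. It also leaves open whether 2-aminoethyl on the same nitrogen of compound 1, whose fluorine sits elsewhere on the core, would give a step of similar size.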